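Benzoxaborole chalcone series: notes on the aryl ketone

The compounds below may be only part of what the source reports. "The series", "measured", "known", "first", "only" and "open" are said of these compounds alone.

Measured so far:
- Compound 1 `O=C(/C=C/c1ccc2c(c1)B(O)OC2)c1ccc(F)cc1` — in a functional assay on SK-OV-3 cells (Homo sapiens) for cytotoxicity, read by MTT assay, with a stated time of 48 h (on this read-out higher numbers stand for weaker inhibition and lower numbers for stronger inhibition), compound 1 gives 1400 nM
- Compound 2 `O=C(/C=C/c1ccc2c(c1)B(O)OC2)c1ccc(Cl)cc1` — in this assay compound 2 gives 3700 nM
- Compound 3 `O=C(/C=C/c1ccc2c(c1)B(O)OC2)c1ccccc1F` — in this assay compound 3 gives 3700 nM

Compound 3 stands level with compound 2 at the digits given; the two share the highest number of the three, the change no change at the digits printed from compound 2 to compound 3 (within the scatter) being within the scatter. Against compound 1 the step of a 2.6-fold higher number from compound 1 to compound 3 (0.42 log units; beyond the scatter) is beyond the scatter and modest, as is a 2.6-fold higher number from compound 1 to compound 2 (0.42 log units; beyond the scatter).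

Compound 4 `O=C(/C=C/c1ccc2c(c1)B(O)OC2)c1ccccc1O` carries the same core as compound 3, with hydroxy in place of fluoro on an aromatic carbon. For the measured compounds named here, no measured step involves a hydroxy group, so none bears directly on this change; the steps between compounds 1, 2 and 3 only show that swapping one halogenated phenyl for another moves this assay by a modest amount at most. Going by the values given here, with no precedent for the hydroxy, the expected outcome for compound 4 is a number close to that of compound 3, within a wide range, the step of a 1.1-fold lower number from compound 3 to compound 4 (0.02 log units; within the scatter) being the estimate. The estimated value for compound 4 in this assay is therefore 3500 nM, between 1200 nM and 10000 nM.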

Compound 4, half-maximal inhibitory concentration: 48800 nM
Estimate against measurement, compound 4: 14-fold (1.14 log units) below; measured number outside the range, above it.
By their numbers in this assay, from the lowest: compound 1; then compounds 2 and 3 (each within the scatter of the next); then compound 4.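

On the aryl ketone, hydroxy in place of fluoro on an aromatic carbon, ortho to a large group, gives a 13-fold higher number from compound 3 to compound 4 (1.12 log units; beyond the scatter) in this assay and shows that this position can move the number far more than the changes among the halogenated compounds 1, 2 and 3 did. The 2-hydroxyphenyl compound also sits well apart from both para-halogenated compounds, with a 13-fold higher number from compound 2 to compound 4 (1.12 log units; beyond the scatter) and a 35-fold higher number from compound 1 to compound 4 (1.54 log units; beyond the scatter) in the same read-out, so the change of substituent outweighs the differences among the halogenated aryl ketones. Nothing available explains this drop in inhibition.

Still open, as far as these compounds go, is whether the large step is specific to hydroxy or would also follow from methoxy or an amine at this place. A carboxylic acid or a longer chain there remains equally undefined.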